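The source may hold more compounds than are shown below. What is called first, only, known or untested is meant among the compounds shown, and "the series" means these compounds.

Measured compounds in a functional assay on HeLa cells (Homo sapiens) for cytotoxicity, read by MTT assay, with a stated time of 48 h, tested at 50 uM; a higher number here means a stronger effect of the compound at the concentration tested, a lower number a weaker effect:
compound 1 `CS(=O)(=O)c1ccc(Cc2n[nH]c(=S)n2/N=C/c2c(F)cccc2Cl)cc1` gives 70.6%
compound 2 `CS(=O)(=O)c1ccc(Cc2n[nH]c(=S)n2/N=C/c2ccc(-c3ccccc3)cc2)cc1` gives 61.6%
compound 3 `CS(=O)(=O)c1ccc(Cc2n[nH]c(=S)n2/N=C/c2ccc(Cl)cc2)cc1` gives 54%

Compound 3 sits at the low end of these three numbers: its gap to compound 2 lies within the scatter, while the step of a number 16.6 percentage points lower from compound 1 to compound 3 (beyond the scatter) lies beyond it. Compound 4 `CS(=O)(=O)c1ccc(Cc2n[nH]c(=S)n2/N=C/c2ccccc2Cl)cc1` differs from compound 3 in one place: 2-chlorophenyl in place of 4-chlorophenyl on a carbon with a double bond to nitrogen. For the measured compounds named here, no measured step exchanges exactly these two groups. The step that bears on it is a number 16.6 percentage points lower from compound 1 to compound 3 (beyond the scatter), since compound 1 carries 2-chloro-6-fluorophenyl at the same carbon; the step of a number 7.6 percentage points lower from compound 2 to compound 3 (within the scatter) stayed within the scatter and says little. A modest rise in this assay is therefore expected for compound 4, estimated at 62% with a range of 48% to 76%. The expected step is a number 8 percentage points higher from compound 3 to compound 4 (within the scatter).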

Compound 4, a percentage reported as activity, at one concentration (the size of the read-out at that concentration, not a potency): 42.7%
Compound 4: middle estimate off by 19.3 percentage points, on the high side, and the stated range ends above it.
By their numbers in this assay, from the lowest: compound 4; then compounds 3, 2 and 1 (each within the scatter of the next, the first and the last beyond it).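

At the carbon with a double bond to nitrogen, 2-chlorophenyl in place of 4-chlorophenyl gives a number 11.3 percentage points lower from compound 3 to compound 4 (beyond the scatter) and so shows that the placing of the chloro alone changes the read-out, with the same atoms present. Hydrogen in place of fluoro on an aromatic carbon gives a number 27.9 percentage points lower from compound 1 to compound 4 (beyond the scatter) and so shows that 2-chlorophenyl does not keep the level of 2-chloro-6-fluorophenyl. No measurement offers a reason for either step. Open, on these data alone, is whether methoxy or an amine in place of that fluoro would keep the level of compound 1, and what plain phenyl gives at this carbon.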